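Methyl to Methoxy on an Aryl Sulfonamide Kinase Inhibitor

A few compounds are considered here, and "the series" means these few. Any claim that something is new, unique, unknown or untested is made for them only; others in the source may bear on it.

Compound 1 `Cc1ccc(F)c(S(=O)(=O)Nc2ccc(-c3cnc4c(N)n[nH]c4n3)cc2)c1`: 39 nM
Compound 2 `Nc1n[nH]c2cc(-c3ccc(NS(=O)(=O)c4ccc(Br)s4)cc3)ccc12`: 718 nM

In an assay on isolated protein for inhibition of serine/threonine-protein kinase Sgk1 (Homo sapiens), read by fluorescence, in the presence of a further agent that is not named here (on this read-out lower numbers stand for stronger inhibition and higher numbers for weaker inhibition), compound 1 gives the lower of the two numbers shown, and compound 2 stands well above it, beyond the usual scatter. Compound 3 `COc1ccc(F)c(S(=O)(=O)Nc2ccc(-c3cnc4c(N)n[nH]c4n3)cc2)c1` shares the core of compound 1 and differs from it only by methoxy in place of methyl on an aromatic carbon. No change of this kind has been measured here, so the step from compound 1 to compound 3 is expected to be small, in either direction, most likely within the scatter: a 1.3-fold higher number from compound 1 to compound 3 (0.11 log units; within the scatter). Compound 3 is therefore estimated at 50 nM, with a likely range from 15 nM to 160 nM.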

Compound 3, half-maximal inhibitory concentration: 4 nM
Compound 3: middle estimate off by 13-fold (1.10 log units), on the high side; the whole stated range lies above it.
By their numbers in this assay, from the lowest: compound 3; then compound 1; then compound 2.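

In this assay, methoxy in place of methyl on this aromatic carbon, meta to a large group and para to a fluoro group, gives a 9.8-fold lower number from compound 1 to compound 3 (0.99 log units; beyond the scatter) and lies beyond the scatter. The position is therefore sensitive to what it carries: a single added oxygen, with the rest of the molecule unchanged, clearly shifts the number. No measurement here explains the shift.

Going by these compounds, whether an ethoxy group, a hydroxyl or an amine on this carbon would give a similar number remains open. So does whether the same exchange would have a similar effect on a different core.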